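The source may hold more compounds than are shown below. What is called first, only, known or untested is meant among the compounds shown, and "the series" means these compounds.

Measured so far:
compound 1, `C=Cc1ccc(OC[C@@H]2CCN2)cn1` — 1.25 nM
compound 2, `N#Cc1cncc(OC[C@@H]2CCN2)c1` — 0.025 nM

In an assay on brain for binding affinity to Neuronal acetylcholine receptor; alpha4/beta2 (Rattus norvegicus), read by radioligand binding (on this read-out lower numbers stand for stronger inhibition and higher numbers for weaker inhibition), compound 2 stands at the lowest number of the two; compound 1 sits well beyond the scatter from it, so compound 2 is clearly the tighter binder here. Compound 3, `NCc1cncc(OC[C@@H]2CCN2)c1`, has not yet been measured. Its change from compound 2 is aminomethyl in place of cyano on an aromatic carbon, a swap of one small group for another of the same size on the same aromatic carbon. For the measured compounds named here, with no comparable step measured, the expected move in this assay for an 80-fold higher number from compound 2 to compound 3 (1.90 log units; beyond the scatter) is a loss beyond the scatter. Compound 3 is therefore estimated at 2 nM, within 0.2 nM to 20 nM.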

Compound 3, inhibition constant: 4.4 nM
The estimate for compound 3 lay 2.2-fold (0.34 log units) below the measured number; measured number inside the range.
By their numbers in this assay, from the lowest: compound 2; then compound 1; then compound 3.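

Swapping cyano for aminomethyl at this aromatic carbon, two atoms from the ring nitrogen, gives in this assay a 180-fold higher number from compound 2 to compound 3 (2.25 log units; beyond the scatter) and is a large loss of binding. Both groups have the same count of heavy atoms, so that count alone does not set the binding at this position; the swap also adds a hydrogen-bond donor. No measurement here accounts for the loss. Still open, on these data alone, is how a methyl, a hydroxymethyl, a carboxylic acid or a longer aminoethyl chain on this carbon would compare with cyano and aminomethyl.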